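Swapping Cyano for Amino on the Shared Core

The source may hold more compounds than are shown below. What is called first, only, known or untested is meant among the compounds shown, and "the series" means these compounds.

Of the compounds shown here, two built on a shared core have been measured. Compound 1 `Cc1ccc2nc(C(=O)c3ccc(F)c(O)c3)ccc2c1` gives 78% in an assay for inhibition of 17-beta-hydroxysteroid dehydrogenase type 2 (Homo sapiens), read by HPLC, with a stated time of 10 min, tested at 1 uM (a lower number here means less inhibition, a higher number more inhibition at the concentration tested (going by the name of the read-out)), while compound 2 `N#Cc1ccc2ccc(C(=O)c3ccc(F)c(O)c3)nc2c1` gives 56% in this assay, the lower of the two numbers, a gap beyond the usual scatter. Compound 3 `Nc1ccc2ccc(C(=O)c3ccc(F)c(O)c3)nc2c1` has not yet been measured; it differs from compound 2 by amino in place of cyano on an aromatic carbon. For the measured compounds named here, no measured pair shows this change, so its effect is not known from the data. Compound 3 is expected to give about 58%, ranging from 38% to 78%. The estimated step of a number 2 percentage points higher from compound 2 to compound 3 (within the scatter) is expected to stay within the usual scatter.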

Compound 3, a percentage reported as inhibition, at one concentration (the size of the read-out at that concentration, not a potency): 83%
For compound 3 the middle estimate is 25 percentage points below the measured one; the whole stated range lies below it.
By their numbers in this assay, from the lowest: compound 2; then compounds 1 and 3 (each within the scatter of the next).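

On this aromatic carbon of the shared core, amino in place of cyano gives a number 27 percentage points higher from compound 2 to compound 3 (beyond the scatter) in this assay. For the compounds shown here, this is the first step read at this position, and it shows that the read-out here depends on which group the carbon carries. Nothing available bears on why the change has this effect. From the compounds shown here alone, whether the higher number is particular to the amino group stays open. A dimethylamino group, an acetamide or a hydroxyl on the same carbon could tell.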